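The source may hold more compounds than are shown below. What is called first, only, known or untested is meant among the compounds shown, and "the series" means these compounds.

Compound 1 `COC(=O)/C=C/n1ccnc1[N+](=O)[O-]` in an ADME assay on Vero cells (Chlorocebus sabaeus) for cytotoxicity, read by CellTiter-Glo, with a stated time of 72 h (a higher number here means that more compound is tolerated, a lower number that less compound is tolerated), gives 16 ug/mL
Compound 2 `[O-][n+]1nc(NC2CC2)[n+]([O-])c2ccccc21` gives 21 ug/mL
Compound 3 `[O-][n+]1nc(NC2CCCCCC2)[n+]([O-])c2ccccc21` gives 7.9 ug/mL

In this assay compound 2 holds the highest number of the three, though its value lies within the scatter of compound 1 and only compound 3 falls beyond the scatter from it. Compound 4 `CCCC(C)Nc1n[n+]([O-])c2ccccc2[n+]1[O-]` follows from compound 2 by one change: 1-methylbutyl in place of cyclopropyl on a nitrogen on an aromatic ring. Among the measured compounds shown here, no measured pair isolates this change. The nearest guide is compound 3 (7.9 ug/mL), which shares the core and also lacks the cyclopropyl, so a modest move to a lower number is expected, not clearly beyond the scatter. The expected change is a 1.9-fold lower number from compound 2 to compound 4 (0.28 log units; within the scatter) in size. Compound 4 is estimated at 11 ug/mL (expected range 5 ug/mL to 22 ug/mL).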

Compound 4, half-maximal cytotoxic concentration: 26 ug/mL
Compound 4: middle estimate off by 2.4-fold (0.37 log units), on the low side, and the stated range ends below it.
By their numbers in this assay, from the lowest: compound 3; then compounds 1, 2 and 4 (each within the scatter of the next).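

In this assay the step is a 1.2-fold higher number from compound 2 to compound 4 (0.09 log units; within the scatter), so at this nitrogen an open 1-methylbutyl chain and the cyclopropyl ring cannot be told apart. Losing the cyclopropyl therefore does not by itself bring the low number seen for compound 3 at 7.9 ug/mL, since compound 4 gives 26 ug/mL. Nothing available accounts for this result.

On these data alone, whether an unbranched pentyl chain would read the same remains open. So does the effect of a chain ending in an amine or a carboxylic acid at this nitrogen.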